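This account rests on a few compounds, and the source may have more. Where it says the series, first, only, none or still open, it means among the compounds named here.

In an assay for binding affinity to 17-beta-hydroxysteroid dehydrogenase type 2 (Homo sapiens), with a stated time of 20 min, tested at 1 uM (on this read-out lower numbers stand for less inhibition and higher numbers for more inhibition at the one concentration tested (going by the name of the read-out)), three compounds built on a shared core have been measured so far. Compound 1 `Oc1ccc2cc(-c3ccccc3O)ccc2c1` reaches only the limit of that assay, reported as < 10%, so no number is known for it (the limit of < 10% in this assay, at which 1 of the 3 values shown sits). Compound 2 `COc1ccc(-c2ccc3c(O)cccc3c2)cc1` gives 20% in this assay, and compound 3 `OCc1ccc(-c2ccc3c(O)cccc3c2)cc1` gives 31%. Among the measured compounds shown here, the one measured step between neighbours, a number 11 percentage points higher from compound 2 to compound 3 (beyond the scatter), is the only guide available, and it is modest. Among the two numbers shown, compound 3 stands highest, with compound 2 nearest and lower by that step.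

Compound 4 `O=[N+]([O-])c1ccc(-c2ccc3c(O)cccc3c2)cc1` is not yet measured. It differs from compound 3 in one place: nitro in place of hydroxymethyl on an aromatic carbon. For the measured compounds named here, no measured step involves a nitro group, so this change cannot be matched directly. Going by the values given here, since the one known swap of a small group on this carbon gave only a modest rise, a further swap of one small group for another is expected to shift the read-out by a comparably small amount, in either direction, or not beyond the scatter at all. Compound 4 is therefore estimated at 25% in this assay, within a range of 5% to 50%. The step this implies, a number 6 percentage points lower from compound 3 to compound 4 (within the scatter), is expected to stay within the scatter.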

Compound 4, a percentage reported as inhibition, at one concentration (the size of the read-out at that concentration, not a potency): 13%
For compound 4 the middle estimate is 12 percentage points above the measured one; the measured number falls inside the stated range.
By their numbers in this assay, from the lowest: compounds 4 and 2 (each within the scatter of the next); then compound 3. At a limit, below all of these: compound 1.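

In this assay, the aromatic carbon para to a large group now shows that the read-out can fall as well as rise with the group placed there, with a number 18 percentage points lower from compound 3 to compound 4 (beyond the scatter). Nitro and methoxy are not told apart at this position, with a number 7 percentage points lower from compound 2 to compound 4 (within the scatter), so among these three groups hydroxymethyl, the one of the swapped pair that carries a hydrogen-bond donor, stands apart from both of the others. Nothing measured here gives a reason for these differences.

On these data alone, what an amine, a carboxylic acid or a longer chain ending in a hydroxyl would give on this same carbon remains open, as does whether any group there could lift the read-out well past that of compound 3. As far as these compounds go, all of these values also come from a single concentration, so how they relate to potency in this assay remains unknown.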